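Swapping one aromatic group on a shared core

The source may report more compounds than this note shows. Statements on the series, on what has been measured and on what is new or still open speak of the compounds shown alone.

Measured in a functional assay on A2058 cells (Homo sapiens) for antiproliferative activity, read by luminescence and CellTiter-Glo, with a stated time of 96 h; on this read-out lower numbers stand for stronger inhibition and higher numbers for weaker inhibition:
- compound 1 `COc1ccc(-c2ccc(F)c(C(=O)Nc3c[nH]nc3C(=O)Nc3ccc(F)cc3)c2F)cn1`: "not determined" (no result reported)
- compound 2 `O=C(Nc1ccc(F)cc1)c1n[nH]cc1NC(=O)c1c(F)ccc(-c2ccncc2)c1F`: 2940 nM
- compound 3 `O=C(Nc1ccc(F)cc1)c1n[nH]cc1NC(=O)c1c(F)ccc(-c2cccc(CO)c2)c1F`: "not determined" (no result reported)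

Compound 3 has no single number in this assay, and compound 1 has none either, so only compound 2 supplies a figure. Compound 4 `Nc1ccc(-c2ccc(F)c(C(=O)Nc3c[nH]nc3C(=O)Nc3ccc(F)cc3)c2F)cn1` differs from compound 3 as follows: 6-aminopyridin-3-yl in place of 3-(hydroxymethyl)phenyl on an aromatic carbon. In words, 6-aminopyridin-3-yl stands in place of 3-(hydroxymethyl)phenyl. Among the measured compounds shown here, no measured step exists to size this change. Compound 2 at 2940 nM is the only anchor, and a moderate step from it toward stronger inhibition is expected, with wide uncertainty. For compound 4 the estimated value is 800 nM, with an expected range of 100 nM to 5000 nM.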

Compound 4, half-maximal inhibitory concentration: 8540 nM
The estimate for compound 4 lay 11-fold (1.03 log units) below the measured number; measured number above the stated range.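

In this assay, changing pyridin-4-yl to 6-aminopyridin-3-yl gives a 2.9-fold higher number from compound 2 to compound 4 (0.46 log units; beyond the scatter), so the group on this aromatic carbon does affect the read-out, and this swap weakens inhibition. Steps to compound 1 and compound 3 cannot be read, as neither has a number. Nothing available explains the loss. The swap moves the ring nitrogen and adds an amine at once, so the two changes cannot be told apart. A plain pyridin-3-yl group would be needed to separate them.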